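Methoxy variation on a shared core: working notes

The source may hold more compounds than are shown below. What is called first, only, known or untested is meant among the compounds shown, and "the series" means these compounds.

Compound 1 `COc1ccc(/C=C2\S/C(=N\c3ccccc3)N(Cc3ccco3)C2=O)cc1OC`: > 250000 nM
Compound 2 `O=C1/C(=C/c2ccccc2)S/C(=N\c2ccccc2)N1Cc1ccco1`: "not determined" (no result reported)

In a toxicity assay on CHO cells (Cricetulus griseus) for cytotoxicity, read by MTT assay, with a stated time of 72 h (a higher number here means a weaker inhibitor, a lower number a stronger inhibitor), compound 1 gives only a limit, > 250000 nM; this is the limit of > 250000 nM in this assay, at which 1 of the 2 values shown sits. Compound 2 has no number in this assay, so it stands nowhere on the scale shown. Compound 3 `COc1ccc(/C=C2\S/C(=N\c3ccccc3)N(Cc3ccco3)C2=O)cc1` differs from compound 2 by methoxy in place of hydrogen on an aromatic carbon. Among the measured compounds shown here, with no measured step, no size or direction is expected in this assay beyond the scatter. Compound 3 is expected, most likely as a limit again, to give 250000 nM, within 100000 nM to 1000000 nM.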

Compound 3, half-maximal inhibitory concentration: > 250000 nM
Compound 3 was reported as a limit; the forecaster's own chance of this, stated with the estimate: 85%; the middle value lies on the limit itself.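

Among the compounds shown here, compound 1 and compound 3 both stand at a limit, so no step between them can be read: the limit of > 250000 nM in this assay, at which 2 of the 3 values shown sit. The compounds shown leave open whether any methoxy variation on the shared core gives a value short of that limit.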